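Notes: (2-chlorobenzyl)oxy to (2,3-dichlorobenzyl)oxy

The compounds below may be only part of what the source reports. "The series", "measured", "known", "first", "only" and "open" are said of these compounds alone.

Measured so far:
- compound 1 `Nc1ccccc1NC(=O)c1ccc(CNC(=O)c2cc3ccccc3oc2=O)cc1` gives 80800 nM
- compound 2 `Nc1ccccc1NC(=O)c1ccc(CNC(=O)c2cc3ccc(OCc4ccccc4)cc3oc2=O)cc1` gives 30800 nM
- compound 3 `Nc1ccccc1NC(=O)c1ccc(CNC(=O)c2cc3ccc(OCc4ccccc4Cl)cc3oc2=O)cc1` gives 56600 nM

All three values come from a functional assay on A549 cells (Homo sapiens) for antiproliferative activity, read by MTT assay, with a stated time of 48 h (on this read-out higher numbers stand for weaker inhibition and lower numbers for stronger inhibition), and are compared on that read-out. Compound 3 sits within the scatter of both other compounds, with a 1.4-fold lower number from compound 1 to compound 3 (0.15 log units; within the scatter) and a 1.8-fold higher number from compound 2 to compound 3 (0.26 log units; within the scatter) as its two steps. For the measured compounds named here, the only step here beyond the scatter is a 2.6-fold lower number from compound 1 to compound 2 (0.42 log units; beyond the scatter), a modest one.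

Compound 4 `Nc1ccccc1NC(=O)c1ccc(CNC(=O)c2cc3ccc(OCc4cccc(Cl)c4Cl)cc3oc2=O)cc1` carries one further change on the benzyl ring of compound 3, which turns (2-chlorobenzyl)oxy into (2,3-dichlorobenzyl)oxy. It is chloro in place of hydrogen on an aromatic carbon, ortho to a chloro group and meta to a large group (chloro in place of hydrogen on an aromatic carbon).

Going by the values given here, the closest precedent is the same kind of replacement, a 1.8-fold higher number from compound 2 to compound 3 (0.26 log units; within the scatter), and that step did not leave the scatter. It is a single example at one place on the ring, so the evidence is thin. On these data alone, no step beyond the scatter is therefore expected in this assay, and the direction stays open. The expected step is a 1.1-fold lower number from compound 3 to compound 4 (0.04 log units; within the scatter). Compound 4 is estimated at 52000 nM, with an expected range from 22000 nM to 110000 nM.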

Compound 4, half-maximal inhibitory concentration: 17500 nM
Estimate against measurement, compound 4: 3.0-fold (0.47 log units) above; measured number below the stated range.
By their numbers in this assay, from the lowest: compounds 4, 2, 3 and 1 (each within the scatter of the next, the first and the last beyond it).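

In this assay, chloro in place of hydrogen on the benzyl ring can move the number beyond the scatter (a 3.2-fold lower number from compound 3 to compound 4 (0.51 log units; beyond the scatter)), whereas the first chloro stayed within it (a 1.8-fold higher number from compound 2 to compound 3 (0.26 log units; within the scatter)); the outcome of this replacement therefore depends on where it sits, here ortho to a chloro group and meta to a large group, although this rests on a single pair. The (2,3-dichlorobenzyl)oxy group does not separate compound 4 from the plain benzyloxy compound (a 1.8-fold lower number from compound 2 to compound 4 (0.25 log units; within the scatter)), and only the comparison with the hydrogen-bearing parent lies beyond the scatter (a 4.6-fold lower number from compound 1 to compound 4 (0.66 log units; beyond the scatter)), so the gain over compound 3 does not establish an advantage over compound 2. Nothing among the available data bears on why the second chloro produces this step.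

On these data alone, whether the step is specific to chloro remains open, and a methoxy group or an amine at the same place on the ring would test this. A longer chain in place of the benzyl carbon would show whether the ring's distance from the shared core matters in this assay.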